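Amide to isobutyl-thiadiazole at the core of compound 1

A few compounds are considered here, and "the series" means these few. Any claim that something is new, unique, unknown or untested is made for them only; others in the source may bear on it.

Measured compounds in an assay on microsomes from liver for inhibition of acyl-CoA desaturase 1 (Rattus norvegicus); on this read-out higher numbers stand for weaker inhibition and lower numbers for stronger inhibition:
compound 1 `O=C(NCCC1CC1)c1ccc(N2CCC(Oc3ccccc3C(F)(F)F)CC2)nn1`, 14 nM
compound 2 `c1cc2c(c(OC3CCN(c4ccc(-n5ccnc5)nn4)CC3)c1)CCC2`, 10 nM
compound 3 `COc1ccccc1OC1CCN(c2ccc(-n3ccnc3)nn2)CC1`, 543 nM

Compound 1 sits second highest of the three numbers in this assay. Its nearest neighbour is compound 2, whose number lies within the scatter of compound 1, so no order between the two can be claimed. Compound 3 is the furthest, beyond the scatter.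

For the measured compounds named here, the only step between measured compounds is a 54-fold higher number from compound 2 to compound 3 (1.73 log units; beyond the scatter), which concerns the aryl group on the oxygen and not the position changed here.

Compound 4 `CC(C)Cc1nnc(-c2ccc(N3CCC(Oc4ccccc4C(F)(F)F)CC3)nn2)s1` differs from compound 1 by 5-isobutyl-1,3,4-thiadiazol-2-yl in place of (2-cyclopropylethyl)carbamoyl on an aromatic carbon. Going by the values given here, no measured step touches this position, so nothing sets a direction for the change. The expectation rests on the surrounding shared core and on the trifluoromethylphenyl group that compound 1 and compound 4 have in common, which in compound 1 gave 14 nM.

Compound 4 is therefore expected to stay close to compound 1, with an estimated step of a 1.4-fold higher number from compound 1 to compound 4 (0.15 log units; within the scatter) and an estimated 20 nM, in a range from 5 nM to 80 nM in this assay.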

Compound 4, half-maximal inhibitory concentration: 37 nM
For compound 4 the middle estimate is 1.9-fold (0.27 log units) below the measured one; the range from low to high includes it.
By their numbers in this assay, from the lowest: compounds 2 and 1 (each within the scatter of the next); then compound 4; then compound 3.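

Working notes on the position para to a large group: in this assay, the only measured step here is a 2.6-fold higher number from compound 1 to compound 4 (0.42 log units; beyond the scatter), on exchanging (2-cyclopropylethyl)carbamoyl for 5-isobutyl-1,3,4-thiadiazol-2-yl. The entering group has no hydrogen-bond donor and compound 4 still gives 37 nM, so with the trifluoromethylphenyl group in place, a donor at this position is not required for inhibition of this order, although the exchange does weaken inhibition beyond the scatter. Nothing available accounts for the size of this step.

The compounds shown do not separate the contribution of the thiadiazole ring from that of the isobutyl chain, since both enter together. Also open, as far as these compounds go, are how a methyl group in place of isobutyl, or a carboxylic acid at this position, would read, and whether the step holds with the 2,3-dihydro-1H-inden-4-yl group on the oxygen.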